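Stripping the ethyl from a bromocatechol ether

A few compounds are considered here, and "the series" means these few. Any claim that something is new, unique, unknown or untested is made for them only; others in the source may bear on it.

Compound 2 `CCOCc1cc(O)c(O)c(Br)c1Br` stands lowest of the two numbers measured in a functional assay on DLD-1 cells (Homo sapiens) for cytotoxicity, read by MTT assay, with a stated time of 96 h (on this read-out lower numbers stand for stronger inhibition and higher numbers for weaker inhibition), where compound 2 gives 13500 nM. Among the compounds with values here, its only neighbour is compound 1 `O=Cc1cc(O)c(O)c(Br)c1Br`, which in this assay gives 30900 nM; the one measured step, a 2.3-fold lower number from compound 1 to compound 2 (0.36 log units; beyond the scatter), exchanged one group on an aromatic carbon for another. The unmeasured compound 3 `OCc1cc(O)c(O)c(Br)c1Br` differs from compound 2 at a different place, (hydrogen in place of ethyl on an oxygen on a saturated carbon). Within the data shown here, no measured step touches this oxygen, so the step from compound 1 to compound 2 bears on it only loosely: it shows that this part of the shared core tolerates changes of modest size. With nothing directly comparable, the step expected in this assay is a 1.3-fold higher number from compound 2 to compound 3 (0.12 log units; within the scatter), which lies within the scatter. Compound 3 is therefore estimated at 18000 nM, with a range from 8000 nM to 40000 nM.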

Compound 3, half-maximal inhibitory concentration: 18300 nM
Beside the measured number, compound 3's estimate is 1.0-fold (0.01 log units) below it, and the stated range covers the measured number.
By their numbers in this assay, from the lowest: compounds 2, 3 and 1 (each within the scatter of the next, the first and the last beyond it).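

Measured in this assay the exchange of ethyl for hydrogen on the oxygen on a saturated carbon gives a 1.4-fold higher number from compound 2 to compound 3 (0.13 log units; within the scatter) and so does not separate the ethoxymethyl from the hydroxymethyl on this read-out. Hydroxymethyl in place of formyl gives a 1.7-fold lower number from compound 1 to compound 3 (0.23 log units; within the scatter) and is also not separated, whereas the earlier step to ethoxymethyl lay beyond the scatter. Only the two ends of this short series, compound 1 and compound 2, are therefore told apart, and compound 3 lies within the scatter of both. No measured evidence here accounts for these numbers. As far as these compounds go, it remains open whether a longer chain such as butyl or an acetyl group on this oxygen would move the number beyond the scatter, and whether an amine or a carboxylic acid in place of the hydroxymethyl would do so.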